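The compounds below may be only part of what the source reports. "The series", "measured", "known", "first", "only" and "open" are said of these compounds alone.

Measured in a functional assay on PANC-1 cells (Homo sapiens) for inhibition, read by XTT assay, with a stated time of 72 h; on this read-out lower numbers stand for stronger inhibition and higher numbers for weaker inhibition:
- compound 1 `Cc1ccc([S+]([O-])N2CCC[C@H]2COCCCCCCCCC/C=C/c2ccc(-c3ccccc3)cc2)cc1`: > 100000 nM (a limit)
- compound 2 `Cc1ccc([S+]([O-])N2CCC[C@H]2COCCCCCCCCC/C=C/c2ccc(Oc3ccccc3)cc2)cc1`: > 100000 nM (a limit)
- compound 3 `CC(=O)N1CCC[C@H]1COCCCCCCCCC/C=C/c1ccc(Oc2ccccc2)cc1`: 65000 nM

Compound 1 gives only a limit, > 100000 nM, and no number. The wider picture is the limit of > 100000 nM in this assay, at which 2 of the 3 values shown sit.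

Compound 4 `CC(C)(C)OC(=O)NCC(=O)N1CCC[C@H]1COCCCCCCCCC/C=C/c1ccc(-c2ccccc2)cc1` keeps the core of compound 1 and changes on the amine nitrogen in a ring, where (((tert-butoxycarbonyl)amino)methyl)carbonyl enters: a group of 11 heavy atoms (7 carbon, 1 nitrogen, 3 oxygen; no ring) in place of a group of 9 heavy atoms (7 carbon, 1 oxygen, 1 sulfur; one six-membered aromatic ring of carbon only), on an amine nitrogen in a ring.

Among the measured compounds shown here, two measured steps bear on this. The closer one is an at least 1.5-fold lower number from compound 2 to compound 3 (0.18 log units; that floor lies within the scatter), in which the same group of 9 heavy atoms leaves the same nitrogen and a smaller group enters. The other is a step that the two limits leave unreadable from compound 1 to compound 2, so no correction can be taken from it for the phenyl that compound 4 shares with compound 1. For the measured compounds named here, the only number is that of compound 3, at 65000 nM, and it anchors the expectation.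

A modest move toward lower numbers is therefore expected in this assay, though a further limit reading would not surprise. The expected step is an at least 1.6-fold lower number from compound 1 to compound 4 (0.22 log units; that floor lies within the scatter). For compound 4 the estimate is 60000 nM, with an expected range of 20000 nM to 150000 nM.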

Compound 4, half-maximal inhibitory concentration: > 100000 nM
Compound 4 ended at the assay's limit (the forecaster's own chance of this, stated with the estimate: 40%); at least 1.6-fold (0.22 log units) between middle value and limit.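

Compound 1 and compound 4 both stand at a limit in this assay, so no step can be read between them. What the compounds shown leave open is whether (((tert-butoxycarbonyl)amino)methyl)carbonyl on the amine nitrogen changes inhibition relative to compound 1, and the series offers little numerical footing for this: the limit of > 100000 nM in this assay, at which 3 of the 4 values shown sit.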